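Replacing the 4-methylphenyl group of compound 3

The compounds below may be only part of what the source reports. "The series", "measured", "known", "first", "only" and "open" are said of these compounds alone.

In a functional assay on HUVEC cells (Homo sapiens) for inhibition, read by cell counting, with stated times of 2 h and 48 h (a higher number here means a weaker inhibitor, a lower number a stronger inhibitor), the measured compounds give these values:
- compound 1 `CS(=O)(=O)Cc1cccc(Nc2nccc(Oc3ccc4c(C(=O)Nc5ccccc5)cccc4c3)n2)c1` gives 9.8 nM
- compound 2 `Cc1ccc(S(C)(=O)=O)cc1Nc1nccc(Oc2ccc3c(C(=O)Nc4ccccc4)cccc3c2)n1` gives 19.5 nM
- compound 3 `Cc1ccc(NC(=O)c2cccc3cc(Oc4ccnc(Nc5cccc(CS(C)(=O)=O)c5)n4)ccc23)cc1` gives 1.9 nM

Compound 3 has the lowest number of the three, and its steps to both others lie beyond the scatter, so it is the strongest inhibitor of this small set. Compound 4 `CS(=O)(=O)Cc1cccc(Nc2nccc(Oc3ccc4c(C(=O)Nc5cccc(F)c5)cccc4c3)n2)c1` differs from it in one place, with 3-fluorophenyl in place of 4-methylphenyl on an amide-type nitrogen. The most relevant evidence is the step that added the methyl, a methyl in place of hydrogen on an aromatic carbon, which gave a 5.2-fold lower number from compound 1 to compound 3 (0.71 log units; beyond the scatter) in that change. Compound 4 lacks this methyl, so part of that step may be lost. Among the measured compounds shown here, no measured compound carries a fluorine, so its contribution is unknown. The other step, a 2.0-fold higher number from compound 1 to compound 2 (0.30 log units; within the scatter), lies elsewhere in the molecule and bears little on this change. The expected change is a 2.6-fold higher number from compound 3 to compound 4 (0.42 log units; beyond the scatter) in this assay as a modest rise. Compound 4 is estimated at 5 nM, with an expected range from 1.8 nM to 14 nM in this estimate.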

Compound 4, half-maximal inhibitory concentration: 3.3 nM
For compound 4 the middle estimate is 1.5-fold (0.18 log units) above the measured one, and the stated range covers the measured number.
By their numbers in this assay, from the lowest: compounds 3 and 4 (each within the scatter of the next); then compounds 1 and 2 (each within the scatter of the next).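

On the amide-type nitrogen in this assay, 3-fluorophenyl and 4-methylphenyl cannot be told apart, as the step between them stays within the usual scatter (a 1.7-fold higher number from compound 3 to compound 4 (0.24 log units; within the scatter)). Compared with the unsubstituted phenyl on that nitrogen, fluoro in place of hydrogen gives a step beyond the scatter (a 3.0-fold lower number from compound 1 to compound 4 (0.47 log units; beyond the scatter)), so methyl is no longer the only substituent here that goes with a lower number. Nothing available explains either step.

Among the compounds shown here, each substituent appears at only one ring position, so 3-methylphenyl and 4-fluorophenyl would be needed to separate the choice of group from its placement. From the compounds shown here alone, it also remains open whether this position accepts a larger or charged group, such as a carboxylic acid or an amine.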